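Swapping an aromatic ring for a saturated oxygen-containing ring

The source may report more compounds than this note shows. Statements on the series, on what has been measured and on what is new or still open speak of the compounds shown alone.

Measured so far:
- Compound 1 `O=C(O)c1ccccc1-c1ccc(CCc2ncc(CC3CCC3)[nH]2)cc1` gives 588 nM in an in vitro functional assay on cells for agonist activity at Bombesin receptor subtype-3 (Homo sapiens), read by luminescence and calcium flux; on this read-out higher numbers stand for an effect only at larger amounts of compound and lower numbers for an effect already at smaller amounts
- Compound 2 `O=C(O)c1ccccc1-c1ccc(CCc2ncc(C3CCCCC3)[nH]2)cc1` gives 375 nM in this assay
- Compound 3 `Cc1ccccc1Cc1cnc(CCc2ccc(-c3ccccc3C(=O)O)cc2)[nH]1` gives 127 nM in this assay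

Compound 3 stands lowest of the three, beyond the scatter from both others. Compound 4 `O=C(O)c1ccccc1-c1ccc(CCc2ncc(CC3CCOCC3)[nH]2)cc1` differs from it by oxan-4-yl in place of 2-methylphenyl on a saturated chain carbon bound to an aromatic carbon. For the measured compounds named here, two steps bear on this: a 4.6-fold lower number from compound 1 to compound 3 (0.67 log units; beyond the scatter) and a 3.0-fold lower number from compound 2 to compound 3 (0.47 log units; beyond the scatter), both showing that a saturated ring in this position gave a higher number than the 2-methylphenyl of compound 3. Since compound 4 returns to a saturated ring, similar in size to those of compound 1 and compound 2, the number is expected to rise again, by about a 3.9-fold higher number from compound 3 to compound 4 (0.60 log units; beyond the scatter). Compound 4 is therefore estimated at 500 nM in this assay, with a range of 200 nM to 1500 nM.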

Compound 4, half-maximal effective concentration: 338 nM
Estimate against measurement, compound 4: 1.5-fold (0.17 log units) above; low and high end bracket the measured number.
By their numbers in this assay, from the lowest: compound 3; then compounds 4, 2 and 1 (each within the scatter of the next).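

In this assay, the oxan-4-yl ring behaves like the other saturated rings, not like the 2-methylphenyl of compound 3 (a 2.7-fold higher number from compound 3 to compound 4 (0.43 log units; beyond the scatter)), a step beyond the scatter. Set against the all-carbon rings, both a 1.1-fold lower number from compound 2 to compound 4 (0.05 log units; within the scatter) and a 1.7-fold lower number from compound 1 to compound 4 (0.24 log units; within the scatter) lie within the scatter, so in these compounds the ring oxygen, with its one hydrogen-bond acceptor, gives no measurable difference. Nothing available here explains these results.

On these data alone, whether a plain phenyl in place of 2-methylphenyl would match compound 3 remains open. So does whether an amine in place of the ring oxygen would match compound 4.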